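A few compounds are considered here, and "the series" means these few. Any claim that something is new, unique, unknown or untested is made for them only; others in the source may bear on it.

Compound 1 `CC(Oc1ccc(Oc2ccc(F)cc2)cc1)C(=O)Cn1nnc(-c2ccccc2)n1` — in an ADME assay on S9 fraction from liver (Rattus norvegicus) for metabolic stability, read by LC-MS, using NADPH, with a stated time of 30 min (on this read-out higher numbers stand for a more stable compound and lower numbers for a less stable compound), compound 1 gives < 5%, which is a limit of the assay and not a number.
Compound 2 `CC(Oc1ccc(-c2ccccc2)cc1)C(=O)Cn1nnc(-c2ccccc2)n1` — in this assay compound 2 gives < 5%, again a limit of the assay.
Compound 3 `COC(=O)c1ccc(-c2nnn(CC(=O)C(C)Oc3ccc(Oc4ccc(F)cc4)cc3)n2)cc1` — in this assay compound 3 gives < 5%, again a limit of the assay.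

Compound 3 therefore stands at the limit, and the two other values shown sit there as well: the limit of < 5% in this assay, at which 3 of the 3 values shown sit. The unmeasured compound 4 `COC(=O)c1ccc(-c2nnn(CC(=O)C(C)Oc3ccc(-c4ccccc4)cc3)n2)cc1` differs from compound 3 in one place, (phenyl in place of 4-fluorophenoxy on an aromatic carbon). The same exchange was measured once before, from compound 1 to compound 2, where the step was a step that the two limits leave unreadable from compound 1 to compound 2. The other measured step, a step that the two limits leave unreadable from compound 1 to compound 3, connects the two series but is equally unreadable. Among the compounds with values here, no measured step gives a size for the change in this assay, in either direction. Compound 4 is expected to stay at the limit, so that the step that the limit leaves unreadable from compound 3 to compound 4 is expected to be unreadable as well. Compound 4 is estimated at 3%, with a range from 0% to 10%.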

Compound 4, percent of the compound remaining: 21%
For compound 4 the middle estimate is 18 percentage points below the measured one; the whole stated range lies below it.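

In this assay, phenyl in place of 4-fluorophenoxy on the ring that carries it gives a number at least 16 percentage points higher from compound 3 to compound 4 (beyond the scatter), and methoxycarbonyl in place of hydrogen gives a number at least 16 percentage points higher from compound 2 to compound 4 (beyond the scatter). The same two exchanges made singly on compound 1 give steps that cannot be read, so among the compounds shown, a readable value appears only where phenyl and methoxycarbonyl occur together. Compound 4 alone stands clear of the limit: the limit of < 5% in this assay, at which 3 of the 4 values shown sit.

Going by these compounds, both readable steps are minimum sizes, so what each exchange contributes on its own remains unknown, and a real effect of either one could lie hidden at the limit. On these data alone, it also remains open whether a carboxylic acid or a nitrile in the place of the methoxycarbonyl group would keep a compound with phenyl off the limit.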